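Shortening the hydroxamate chain on two related cores

A few compounds are considered here, and "the series" means these few. Any claim that something is new, unique, unknown or untested is made for them only; others in the source may bear on it.

Three compounds have been measured in a functional assay on HCT-116 cells (Homo sapiens) for inhibition, read by MTT assay, with a stated time of 72 h; on this read-out higher numbers stand for weaker inhibition and lower numbers for stronger inhibition:
Compound 1 `Nc1ncnc2c1c(-c1cnc3[nH]ccc3c1)nn2CCCCCCCCC(=O)NO` gives 5460 nM.
Compound 2 `Nc1ncnc2c1c(-c1cnc3[nH]ccc3c1)nn2CCCCC(=O)NO` reaches only a limit of the assay, > 150000 nM.
Compound 3 `Nc1nc2cc(-c3nn(CCCCCC(=O)NO)c4ncnc(N)c34)ccc2o1` gives 21500 nM.

The difference between the core of compound 1 and the core of compound 3 is not broken down here. On the first core, the change hydroxycarbamoyl in place of 4-(hydroxycarbamoyl)butyl on a saturated chain carbon, four bonds along the chain from an aromatic nitrogen produced an at least 27-fold higher number from compound 1 to compound 2 (1.43 log units; beyond the scatter), running into (the limit of > 150000 nM in this assay, at which 1 of the 3 values shown sits). Compound 4 `Nc1nc2cc(-c3nn(CC(=O)NO)c4ncnc(N)c34)ccc2o1` carries the same kind of change on the core of compound 3, (hydroxycarbamoyl in place of 4-(hydroxycarbamoyl)butyl on a saturated chain carbon bound to an aromatic nitrogen); the place is not identical, since here the chain carbon is bound to an aromatic nitrogen rather than four bonds along the chain from one. The expected step is a 9.3-fold higher number from compound 3 to compound 4 (0.97 log units; beyond the scatter). That expectation rests on compound 3 starting at 21500 nM and on the earlier shortening giving an at least 27-fold higher number from compound 1 to compound 2 (1.43 log units; beyond the scatter). Compound 4 is therefore estimated at 200000 nM, quite possibly reported only as a limit.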

Compound 4, half-maximal inhibitory concentration: 11400 nM
For compound 4 the middle estimate is 18-fold (1.24 log units) above the measured one; measured number outside the range, below it.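

On the core of compound 3, putting hydroxycarbamoyl in place of 4-(hydroxycarbamoyl)butyl gives a 1.9-fold lower number from compound 3 to compound 4 (0.28 log units; within the scatter) in this assay, so compound 3 and compound 4 cannot be told apart here. The same change therefore did not carry over from one core to the other: the same change on two cores in this assay, an at least 27-fold higher number (1.43 log units; beyond the scatter) from compound 1 to compound 2 and a 1.9-fold lower number (0.28 log units; within the scatter) from compound 3 to compound 4, at least 51-fold (1.71 log units) apart, beyond the scatter of two such steps. This does not show why, since the two pairs differ in the core and also in the place of the change on the chain, and the compounds shown cannot separate the two.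

On these data alone, compound 2 stands only at a limit (> 150000 nM), so the true size of the earlier step stays open. Also open, as far as these compounds go, is how a longer chain on the core of compound 3 would read in this assay.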